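From 4-chlorophenyl to 3-methylphenyl in a cell toxicity test

A few compounds are considered here, and "the series" means these few. Any claim that something is new, unique, unknown or untested is made for them only; others in the source may bear on it.

In a toxicity assay on THP-1 cells (Homo sapiens) for inhibition (on this read-out lower numbers stand for higher toxicity in this test and higher numbers for lower toxicity in this test), compound 1 `Cn1c(-c2ccc(Br)cc2)cnc1NC(=O)c1ccc(F)cc1` gives 46000 nM and compound 2 `Cn1c(-c2ccc(Cl)cc2)cnc1NC(=O)c1ccc(F)cc1` gives 37000 nM. Among the compounds with values here, the only measured step is a 1.2-fold lower number from compound 1 to compound 2 (0.09 log units; within the scatter), so compound 2 stands level with compound 1 on the numbers available. Compound 3 `Cc1cccc(-c2cnc(NC(=O)c3ccc(F)cc3)n2C)c1` keeps the shared core but carries 3-methylphenyl in place of 4-chlorophenyl on an aromatic carbon. Within the data shown here, only one measured step bears on this change, and it offers limited guidance. That step exchanged chloro for bromo, whereas compound 3 brings a methyl group and a different substitution pattern on the phenyl ring. Still, the step to compound 2 is the only size available, and it stayed within the scatter. With so little evidence, no clear direction can be argued, and compound 2 at 37000 nM serves as the starting point. The expected step is a 1.1-fold higher number from compound 2 to compound 3 (0.03 log units; within the scatter), which means no change beyond the scatter is anticipated. For compound 3 the estimated value in this assay is 40000 nM, with an expected range of 18000 nM to 90000 nM.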

Compound 3, half-maximal cytotoxic concentration: > 100000 nM
Compound 3 gave a limit, no number; the forecaster's own chance of this, stated with the estimate: 20%; middle value at least 2.5-fold (0.39 log units) away from the limit.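

In this assay, compound 3 gives a limit of the assay and not a number: the limit of > 100000 nM in this assay, at which 1 of the 3 values shown sits.

Even so, the limit is enough to show a real move, with an at least 2.7-fold higher number from compound 2 to compound 3 (0.43 log units; beyond the scatter) and an at least 2.1-fold higher number from compound 1 to compound 3 (0.33 log units; beyond the scatter), both toward lower toxicity in this test, whereas the exchange of bromo for chloro in the earlier pair stayed within the scatter. On these data alone, this aromatic carbon of the shared core is therefore not indifferent to the phenyl group it carries, although the full size of both steps remains unknown.

The change to 3-methylphenyl does two things at once, replacing a halogen with a methyl group and altering where the substituent sits on the phenyl ring, so the compounds shown cannot say which of the two matters, or whether both are needed. As far as these compounds go, it also remains open whether a methoxy group or an amine on that phenyl ring would give a similarly low toxicity in this assay, or whether the effect is particular to methyl.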